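The source may hold more compounds than are shown below. What is called first, only, known or untested is meant among the compounds shown, and "the series" means these compounds.

Measured so far, in a functional assay on HeLa cells (Homo sapiens) for inhibition, read by MTT assay, with a stated time of 72 h; on this read-out lower numbers stand for stronger inhibition and higher numbers for weaker inhibition:

Compound 1 `CNC(=O)CCCCCCCn1nc(-c2cnc3[nH]ccc3c2)c2c(N)ncnc21` gives 29100 nM.
Compound 2 `Nc1ncnc2c1c(-c1cnc3[nH]ccc3c1)nn2CCCCCCC(=O)NO` gives 22000 nM.
Compound 3 `CNC(=O)CCCCCCCn1nc(-c2ccc3oc(N)nc3c2)c2c(N)ncnc21` gives 12900 nM.

Compound 1 and compound 2 share a core and differ in one place: hydroxycarbamoyl in place of (methylcarbamoyl)methyl on a saturated chain carbon, six bonds along the chain from an aromatic nitrogen. This change brought a 1.3-fold lower number from compound 1 to compound 2 (0.12 log units; within the scatter), so the two numbers are not distinguishable here. Compound 3 keeps the chain of compound 1 but carries a different group on the core: a group of 10 heavy atoms (7 carbon, 2 nitrogen, 1 oxygen; one five-membered aromatic ring with 2 hetero atoms, one six-membered aromatic ring of carbon only) in place of a group of 9 heavy atoms (7 carbon, 2 nitrogen; one five-membered aromatic ring with 1 hetero atom, one six-membered aromatic ring with 1 hetero atom), on an aromatic carbon. That exchange gave a 2.3-fold lower number from compound 1 to compound 3 (0.35 log units; beyond the scatter), a modest gain, and compound 3 stands with the lowest number of the three, although its gap to compound 2 is within the scatter.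

Compound 4 `Nc1nc2cc(-c3nn(CCCCCCC(=O)NO)c4ncnc(N)c34)ccc2o1` has not yet been measured. It combines the core of compound 3 with the chain end of compound 2, and from compound 3 it differs by hydroxycarbamoyl in place of (methylcarbamoyl)methyl on a saturated chain carbon, six bonds along the chain from an aromatic nitrogen. Among the compounds with values here, this is the same change as the one from compound 1 to compound 2, made at the same place on the chain.

Within the data shown here, on that basis the step from compound 3 to compound 4 is expected to be a 1.3-fold lower number from compound 3 to compound 4 (0.11 log units; within the scatter), close to the earlier 1.3-fold lower number from compound 1 to compound 2 (0.12 log units; within the scatter), since the only evidence for this change is that single pair and it produced no step beyond the scatter. Compound 4 is therefore estimated at 10000 nM in this assay, with a range from 4000 nM to 25000 nM.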

Compound 4, half-maximal inhibitory concentration: 6410 nM
The estimate for compound 4 lay 1.6-fold (0.19 log units) above the measured number; the measured number falls inside the stated range.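

In this assay, within the data shown here, putting hydroxycarbamoyl in place of (methylcarbamoyl)methyl on the core of compound 3 gave a 2.0-fold lower number from compound 3 to compound 4 (0.30 log units; within the scatter), and this step reads much like the one for the same change on the other core: the same change on two cores in this assay, a 1.3-fold lower number (0.12 log units; within the scatter) from compound 1 to compound 2 and a 2.0-fold lower number (0.30 log units; within the scatter) from compound 3 to compound 4, 1.5-fold (0.18 log units) apart, within the scatter of two such steps. The exchange of the group on the aromatic carbon, read with the hydroxycarbamoyl chain end in place, gave a 3.4-fold lower number from compound 2 to compound 4 (0.54 log units; beyond the scatter), and this step too agrees with its earlier counterpart: the same change on two cores in this assay, a 2.3-fold lower number (0.35 log units; beyond the scatter) from compound 1 to compound 3 and a 3.4-fold lower number (0.54 log units; beyond the scatter) from compound 2 to compound 4, 1.5-fold (0.18 log units) apart, within the scatter of two such steps. Across these four compounds, each change therefore carries from one core to the other without a difference that can be told from the scatter, and only the exchange on the aromatic carbon gives steps beyond the scatter, but this rests on just two pairs per change in a single assay and does not show that either change would behave alike on any further core, nor why the steps agree.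

The compounds shown leave open how a carboxylic acid or a primary amide at the chain end would read in this assay, and how a shorter or a longer chain would read there. They also leave open whether the chain-end exchange would keep the same size with a third group, such as phenyl, on the aromatic carbon.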